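From 4-Methylphenyl to 2-Methoxyphenyl on a Shared Core

The source may report more compounds than this note shows. Statements on the series, on what has been measured and on what is new or still open speak of the compounds shown alone.

In a functional assay on MDA-MB-231 cells (Homo sapiens) for inhibition, read by MTT assay, with a stated time of 72 h (on this read-out lower numbers stand for stronger inhibition and higher numbers for weaker inhibition), compound 1 `CC1=NN(c2ccccc2)C(=O)[C@]12C(=O)C=CC[C@H]2c1ccc(C)cc1` gives 5720 nM. Its stereoisomer compound 2 `CC1=NN(c2ccccc2)C(=O)[C@@]12C(=O)C=CC[C@H]2c1ccc(C)cc1` gives 8300 nM, and a further stereoisomer, compound 3 `CC1=NN(c2ccccc2)C(=O)[C@]12C(=O)C=CC[C@@H]2c1ccc(C)cc1`, gives 6240 nM. Compound 1 therefore stands within the scatter of both others: the series shows a 1.5-fold higher number from compound 1 to compound 2 (0.16 log units; within the scatter) and a 1.1-fold higher number from compound 1 to compound 3 (0.04 log units; within the scatter), and the mirror-image pair shows a 1.3-fold lower number from compound 2 to compound 3 (0.12 log units; within the scatter).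

Compound 4 `COc1ccccc1[C@@H]1CC=CC(=O)[C@]12C(=O)N(c1ccccc1)N=C2C` keeps the shared core but carries a different group: 2-methoxyphenyl in place of 4-methylphenyl on a saturated ring carbon. In short, 2-methoxyphenyl stands in place of 4-methylphenyl on a saturated ring carbon. The measured steps bear on this change only indirectly, as they concern (the fact that compounds 1 and 2 differ only in the configuration as drawn), the fact that compounds 1 and 3 differ only in the configuration as drawn and (the fact that compounds 2 and 3 differ only in the configuration as drawn). None of them exchanges a group, so the data give no direct measure of this replacement and no direction for it. The expectation therefore rests on compound 1 at 5720 nM and on the narrow spread of its stereoisomers, and no step beyond the scatter is expected in this assay. The estimated change is a 1.1-fold higher number from compound 1 to compound 4 (0.06 log units; within the scatter). For compound 4 the expected value is 6500 nM, with an estimated range from 2500 nM to 16000 nM.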

Compound 4, half-maximal inhibitory concentration: 5140 nM
The estimate for compound 4 lay 1.3-fold (0.10 log units) above the measured number; measured number inside the range.
By their numbers in this assay, from the lowest: compounds 4, 1, 3 and 2 (each within the scatter of the next).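

In this assay, exchanging 4-methylphenyl for 2-methoxyphenyl on the saturated ring carbon gives a 1.1-fold lower number from compound 1 to compound 4 (0.05 log units; within the scatter). This is the only step shown that exchanges a group rather than a configuration as drawn, so it gives the first direct reading at this position: replacing the 4-methylphenyl group with one that has a hydrogen-bond acceptor and one more heavy atom does not move the number beyond the scatter. None of the available evidence bears on why this exchange leaves the number within the scatter, as the earlier steps concern only configuration as drawn.

On these data alone, whether the stereoisomers of compound 4 would lie as close together as those of compound 1 remains open. Also open, as far as these compounds go, is whether this position would respond in the same way to a group of a different kind, such as an amine, a carboxylic acid or a longer chain in place of the aromatic group, since the two groups compared here are both substituted phenyl rings.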